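Exchanging the Amide Substituent: Compound 1 to Compound 3

This account rests on a few compounds, and the source may have more. Where it says the series, first, only, none or still open, it means among the compounds named here.

Measured so far:
Compound 1 `CN(C)CC(=O)N1CCC(NS(=O)(=O)c2cc(S(=O)(=O)c3ccccc3)ccc2C(F)(F)F)CC1` gives 300 nM in an assay on isolated protein for binding affinity to secreted frizzled-related protein 1 (Homo sapiens), read by fluorescence; on this read-out higher numbers stand for weaker inhibition and lower numbers for stronger inhibition.
Compound 2 `O=C(CN1CCCC1)N1CCC(NS(=O)(=O)c2cc(S(=O)(=O)c3ccccc3)ccc2C(F)(F)F)CC1` gives 110 nM in this assay.

Compound 1 holds the highest of the two numbers in this assay; its nearest neighbour is compound 2, reached through a 2.7-fold lower number from compound 1 to compound 2 (0.44 log units; beyond the scatter). Among the measured compounds shown here, that single step, pyrrolidin-1-yl in place of dimethylamino on a saturated chain carbon bound to a carbonyl carbon, is the only measured change in this set, and it is modest.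

Compound 3 `CN(C)C(=O)N1CCC[C@H]1C(=O)N1CCC(NS(=O)(=O)c2cc(S(=O)(=O)c3ccccc3)ccc2C(F)(F)F)CC1` is not yet measured. It differs from compound 1 by 1-(dimethylcarbamoyl)pyrrolidin-2-yl in place of (dimethylamino)methyl on a carbonyl carbon. This is a larger change than the step from compound 1 to compound 2: the whole (dimethylamino)methyl group leaves, and a five-membered ring carrying a carbamoyl group enters, with one defined stereocentre. The measured step offers only loose guidance, since it kept a basic amine in place while compound 3 does not.

Compound 3 is therefore expected to land near compound 1, with a 1.2-fold lower number from compound 1 to compound 3 (0.08 log units; within the scatter) and wide uncertainty, estimated at 250 nM within 60 nM to 1000 nM.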

Compound 3, half-maximal inhibitory concentration: 30 nM
For compound 3 the middle estimate is 8.3-fold (0.92 log units) above the measured one, outside the stated range (below it).
By their numbers in this assay, from the lowest: compound 3; then compound 2; then compound 1.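

The position on the carbonyl carbon bound to the amide-type ring nitrogen accepts far more than the small swap between compound 1 and compound 2 could show: in this assay, 1-(dimethylcarbamoyl)pyrrolidin-2-yl, with 10 heavy atoms in place of 4, gives a 10-fold lower number from compound 1 to compound 3 (1.00 log units; beyond the scatter) as the result of this change. Compared with the pyrrolidine-bearing side chain, the same group gives a 3.7-fold lower number from compound 2 to compound 3 (0.56 log units; beyond the scatter) in the same direction, so compound 3 has the lowest number of the three, and both steps lie beyond the scatter. An amine on a one-carbon chain is therefore not needed at this position for a low number, although nothing shown gives a reason for the gain.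

The change brings in a ring, a dimethylcarbamoyl group and a defined stereocentre all at once, and the compounds shown do not tell which of these accounts for the lower number. A pyrrolidin-2-yl group with a plain hydrogen on its ring nitrogen, an acetyl group in place of dimethylcarbamoyl, or the mirror-image form of the stereocentre would each separate these contributions.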